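Replacing the 4-chlorophenyl group of compound 3

The source may report more compounds than this note shows. Statements on the series, on what has been measured and on what is new or still open speak of the compounds shown alone.

Of the compounds shown here, three that share one core have been tested in a functional assay on MCF7 cells (Homo sapiens) for cytotoxicity, read by MTT assay, with a stated time of 72 h; a higher number here means a weaker inhibitor, a lower number a stronger inhibitor. Compound 1 `CC(C)=C1C(=O)N(c2ccc(Cl)cc2)N(c2ccc(Cl)cc2)C1=O` gives 39600 nM. Compound 3 `O=C1C(=Cc2ccc(Cl)cc2)C(=O)N(c2ccc(Cl)cc2)N1c1ccc(Cl)cc1` gives 28500 nM, and these two values lie within the scatter of each other. Compound 2 `CN(C)c1ccc(C=C2C(=O)N(c3ccc(Cl)cc3)N(c3ccc(Cl)cc3)C2=O)cc1` reads > 128000 nM, which is a limit of the assay and not a number.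

Compound 4 `COc1cccc(C=C2C(=O)N(c3ccc(Cl)cc3)N(c3ccc(Cl)cc3)C2=O)c1O` is still unmeasured. It differs from compound 3 by a single change, with 2-hydroxy-3-methoxyphenyl in place of 4-chlorophenyl on a double-bonded chain carbon bound to a double-bonded ring carbon.

Among the measured compounds shown here, one measured step bears on this change, as it also alters the aromatic group at that place: an at least 4.4-fold lower number from compound 2 to compound 3 (0.65 log units; beyond the scatter). Its size is known only as a bound, since one end of it is a limit, but it lies beyond the scatter. Given that step, a modest move to a higher number is expected in this assay once the chloro group of compound 3 is gone. A single pair is thin support, so the expectation is loose. The estimated step is a 1.8-fold higher number from compound 3 to compound 4 (0.24 log units; within the scatter). For compound 4 the expected value is 50000 nM, with an estimated range from 18000 nM to 120000 nM.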

Compound 4, half-maximal inhibitory concentration: 26700 nM
For compound 4 the middle estimate is 1.9-fold (0.27 log units) above the measured one; measured number inside the range.
By their numbers in this assay, from the lowest: compounds 4, 3 and 1 (each within the scatter of the next). At a limit, above all of these: compound 2.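

In this assay, 2-hydroxy-3-methoxyphenyl in place of 4-chlorophenyl on a double-bonded chain carbon bound to a double-bonded ring carbon gives a 1.1-fold lower number from compound 3 to compound 4 (0.03 log units; within the scatter), so the chloro group is not needed at this place to keep a reading of this size. Swapping a 4-(dimethylamino)phenyl group for the same 2-hydroxy-3-methoxyphenyl group gives an at least 4.7-fold lower number from compound 2 to compound 4 (0.68 log units; beyond the scatter), which shows that losing the chloro group does not by itself carry the number up to the level of compound 2: among the aromatic groups shown at this place, compound 2 is the one that goes against the others. Compound 2 reads as a limit of the assay and not a number, so this step is known only as a bound: the limit of > 128000 nM in this assay, at which 1 of the 4 values shown sits.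

The hydroxy and methoxy groups enter together in compound 4, so the compounds shown cannot separate what each contributes, and no reason for the gap to compound 2 can be read from them. On these data alone, how a plain phenyl ring, or a phenyl ring carrying a carboxylic acid or a primary amine, would read at this place remains open.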